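The compounds below may be only part of what the source reports. "The series", "measured", "known", "first", "only" and "open" are said of these compounds alone.

Measured compounds in a functional assay on NCI-H1975 cells (Homo sapiens) for inhibition, read by MTT assay, with a stated time of 72 h; a higher number here means a weaker inhibitor, a lower number a stronger inhibitor:
- compound 1, `CCOc1cc2ncnc(Nc3ccc(F)c(Cl)c3)c2cc1OC(=O)CSc1ccccn1`, gives 3700 nM
- compound 2, `CCOc1cc2ncnc(Nc3ccc(F)c(Cl)c3)c2cc1OC(=O)CSc1nccn1C`, gives 6900 nM
- compound 3, `CCOc1cc2ncnc(Nc3ccc(F)c(Cl)c3)c2cc1OC(=O)CSc1nc2ccccc2s1`, gives 9800 nM

Compound 1 stands at the lowest number of the three in this assay. The gap to compound 2 is within the scatter (a 1.9-fold higher number from compound 1 to compound 2 (0.27 log units; within the scatter)), so no order between those two can be claimed; the gap to compound 3 is beyond it (a 2.6-fold higher number from compound 1 to compound 3 (0.42 log units; beyond the scatter)), a modest rise. Between compound 2 and compound 3 the step is again within the scatter (a 1.4-fold higher number from compound 2 to compound 3 (0.15 log units; within the scatter)).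

Compound 4, `CCOc1cc2ncnc(Nc3ccc(F)c(Cl)c3)c2cc1OC(=O)CSc1nc2cc(OC)ccc2s1`, differs from compound 1 by 5-methoxy-1,3-benzothiazol-2-yl in place of pyridin-2-yl on a sulfur. For the measured compounds named here, the step that bears on it most directly is the one to compound 3, where the same ring system without the methoxy group entered on the same sulfur and gave a modest rise in the number. Going by the values given here, the methoxy group itself has no measured counterpart, so its own contribution is unknown. The expectation is therefore a step of about the size seen toward compound 3, upward, rather than none: compound 4 is expected to give 9500 nM in this assay, with a range of 4000 nM to 23000 nM, which corresponds to an estimated 2.6-fold higher number from compound 1 to compound 4 (0.41 log units; beyond the scatter).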

Compound 4, half-maximal inhibitory concentration: 3200 nM
Compound 4: middle estimate off by 3.0-fold (0.47 log units), on the high side; measured number outside the range, below it.
By their numbers in this assay, from the lowest: compounds 4, 1, 2 and 3 (each within the scatter of the next, the first and the last beyond it).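

Methoxy in place of hydrogen on an aromatic carbon of the 1,3-benzothiazol-2-yl group is the first change in the series that keeps the group on the sulfur and alters only its substitution, and in this assay it gives a modest drop (a 3.1-fold lower number from compound 3 to compound 4 (0.49 log units; beyond the scatter)). The identity of the ring system on the sulfur therefore does not fix the number alone: 5-methoxy-1,3-benzothiazol-2-yl cannot be ordered against pyridin-2-yl (a 1.2-fold lower number from compound 1 to compound 4 (0.06 log units; within the scatter)), although the unsubstituted group stood higher than pyridin-2-yl. It also separates from 1-methyl-1H-imidazol-2-yl (a 2.2-fold lower number from compound 2 to compound 4 (0.33 log units; beyond the scatter)), a separation that pyridin-2-yl did not show.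

From the compounds shown here alone, whether a hydroxy group, a fluorine or an amine on the same aromatic carbon would lower the number likewise remains open. No available evidence explains the effect of the methoxy group.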